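A few compounds are considered here, and "the series" means these few. Any claim that something is new, unique, unknown or untested is made for them only; others in the source may bear on it.

Working notes on the series. Going by the values given here, compound 3 `C/C=C/C(=O)Nc1ccc(Cn2nc(-c3ccc(Oc4ccccc4)cc3)cc2CO)cc1` gives 48400 nM in a functional assay on Maver1 cells (Homo sapiens) for inhibition, read by luminescence and CellTiter-Glo, with a stated time of 72 h (a lower number here means a stronger inhibitor, a higher number a weaker inhibitor), the highest of the three numbers so far. Compound 1 `O=C(CCl)Nc1ccc(Cn2nc(-c3ccc(Oc4ccccc4)cc3)cc2CO)cc1` gives 400 nM in this assay, and compound 2 `C=CC(=O)Nc1ccc(Cn2nc(-c3ccc(Oc4ccccc4)cc3)cc2C(=O)OCC)cc1` gives 13300 nM in the same assay. Among the compounds with values here, the only measured step on the amide end is a 120-fold higher number from compound 1 to compound 3 (2.08 log units; beyond the scatter), a large loss on moving away from chloromethyl. Compound 4 `C=CC(=O)Nc1ccc(Cn2nc(-c3ccc(Oc4ccccc4)cc3)cc2CO)cc1` is still to be measured; against compound 3 the change is vinyl in place of prop-1-en-1-yl on a carbonyl carbon. Within the data shown here, no measured pair isolates this change. Compound 2 carries the vinylcarbonyl group that enters here, though with an ester where compound 3 has hydroxymethyl, so its value in this assay is only an indirect pointer. On that pointer, and on the large step seen between the two warheads already measured, the expectation for compound 4 is a step downward beyond the scatter, a 9.7-fold lower number from compound 3 to compound 4 (0.99 log units; beyond the scatter), but short of the number for compound 1. The estimate for compound 4 in this assay is 5000 nM, with a range of 1500 nM to 20000 nM.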

Compound 4, half-maximal inhibitory concentration: 7000 nM
Compound 4: middle estimate off by 1.4-fold (0.15 log units), on the low side; low and high end bracket the measured number.
By their numbers in this assay, from the lowest: compound 1; then compounds 4 and 2 (each within the scatter of the next); then compound 3.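

In this assay, going by these compounds alone, the step of a 6.9-fold lower number from compound 3 to compound 4 (0.84 log units; beyond the scatter) gives the first direct reading of vinyl against prop-1-en-1-yl on a carbonyl carbon with hydroxymethyl held fixed, showing that the group on the amide carbonyl changes the number even between these two alkenes. Vinyl does not match chloromethyl at this position, as the step of an 18-fold higher number from compound 1 to compound 4 (1.24 log units; beyond the scatter) shows. With vinylcarbonyl in place, the step of a 1.9-fold lower number from compound 2 to compound 4 (0.28 log units; within the scatter) does not separate hydroxymethyl from ethoxycarbonyl on the aromatic carbon.

No measurement here accounts for these differences. Still open, on these data alone, is whether ethoxycarbonyl would read the same alongside chloromethyl, and how bromomethyl on the carbonyl carbon or a carboxylic acid on the aromatic carbon would compare.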